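The source may report more compounds than this note shows. Statements on the series, on what has been measured and on what is new or still open speak of the compounds shown alone.

Measured so far:
- compound 1, `O=C(Nc1ccc(Oc2ccnc3[nH]ccc23)cc1)c1cc2cccnc2n(-c2ccccc2)c1=O`: 380 nM
- compound 2, `O=C(Nc1ccc(Oc2ccnc3[nH]ccc23)cc1)c1cc2cccnc2n(-c2ccc(C(F)(F)F)cc2Cl)c1=O`: 1950 nM
- compound 3, `O=C(Nc1ccc(Oc2ccnc3[nH]ccc23)c(F)c1)c1cc2cccnc2n(-c2ccccc2)c1=O`: 180 nM

These three compounds were tested in a functional assay on NCI-H460 cells (Homo sapiens) for antiproliferative activity, read by MTT assay, with a stated time of 72 h; a lower number here means a stronger inhibitor, a higher number a weaker inhibitor. Compound 3 gives the lowest number of the three: compound 1 is a 2.1-fold lower number from compound 1 to compound 3 (0.32 log units; beyond the scatter) behind it, and compound 2 is further off still, so on these numbers compound 3 is the strongest of the set.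

Compound 4, `O=C(Nc1ccc(Oc2ccnc3[nH]ccc23)c(F)c1)c1cc2cccnc2n(-c2ccc(F)c(Cl)c2)c1=O`, has not been measured. It keeps the fluoro of compound 3 and changes the ring attached to the aromatic nitrogen of the shared core: 3-chloro-4-fluorophenyl in place of phenyl on an aromatic nitrogen.

Within the data shown here, only one measured step touches that position. Going from compound 1 to compound 2, a 2-chloro-4-(trifluoromethyl)phenyl replaced the phenyl there and gave a 5.1-fold higher number from compound 1 to compound 2 (0.71 log units; beyond the scatter), a clear weakening. The group entering compound 4 is a different, smaller substituted phenyl, so that step is a pointer rather than a template. A weakening of comparable or lesser size is expected, giving a 2.2-fold higher number from compound 3 to compound 4 (0.35 log units; beyond the scatter) as the estimated step. Compound 4 is therefore expected to give about 400 nM, within 130 nM to 1200 nM.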

Compound 4, half-maximal inhibitory concentration: 1050 nM
Beside the measured number, compound 4's estimate is 2.6-fold (0.42 log units) below it; low and high end bracket the measured number.
By their numbers in this assay, from the lowest: compound 3; then compound 1; then compounds 4 and 2 (each within the scatter of the next).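

Compound 4 shows that the weakening at this position is not tied to the particular group in compound 2: 3-chloro-4-fluorophenyl in place of phenyl on the aromatic nitrogen gives a 5.8-fold higher number from compound 3 to compound 4 (0.77 log units; beyond the scatter) in this assay. It also shows that the same kind of change weakens compounds carrying the added fluoro, since the earlier step, a 5.1-fold higher number from compound 1 to compound 2 (0.71 log units; beyond the scatter), came from compounds without it. In both pairs shown, the plain phenyl gives the lower number, and no compound here goes against this, though no measurement offered here explains it. The compounds shown leave open whether a single chloro or a single fluoro on that phenyl would be enough to raise the number. They also leave open how a methyl, a longer chain or a pyridine ring would behave on that nitrogen.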